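Swapping methoxy for fluoro on compound 3

The compounds below may be only part of what the source reports. "The series", "measured", "known", "first", "only" and "open" are said of these compounds alone.

Compound 1 `C#CCn1c(=O)c(C=O)cc2cc(OC)ccc21`: > 100000 nM, a limit of the assay and not a number
Compound 2 `C#CCn1c(=O)c(/C=C/C(=O)/C=C(O)/C=C/c2ccc(O)c(OC)c2)cc2ccccc21`: 19000 nM
Compound 3 `C#CCn1c(=O)c(/C=C/C(=O)/C=C(O)/C=C/c2ccc(O)c(OC)c2)cc2cc(OC)ccc21`: 14000 nM

In a functional assay on SK-OV-3 cells (Homo sapiens) for cytotoxicity, read by MTT assay, with a stated time of 24 h (on this read-out higher numbers stand for weaker inhibition and lower numbers for stronger inhibition), compound 3 gives 14000 nM, and compound 2 gives 19000 nM. These two values lie within the scatter of each other, so neither stands out from the other.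

The next compound, compound 4 `C#CCn1c(=O)c(/C=C/C(=O)/C=C(O)/C=C/c2ccc(O)c(OC)c2)cc2cc(F)ccc21`, carries fluoro in place of methoxy on an aromatic carbon.

Within the data shown here, only one measured step bears on this change. Putting methoxy in place of hydrogen on an aromatic carbon gave a 1.4-fold lower number from compound 2 to compound 3 (0.13 log units; within the scatter), which is no real change. With hydrogen and methoxy giving matching values in this assay, fluoro is not expected to shift the number beyond the scatter either. This rests on a single step, so the expectation is loose.

The estimated step is a 1.1-fold higher number from compound 3 to compound 4 (0.03 log units; within the scatter).

For compound 4 the estimated value is 15000 nM, with an expected range from 6000 nM to 36000 nM.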

Compound 4, half-maximal inhibitory concentration: > 100000 nM
Compound 4: no number, only a limit (the forecaster's own chance of this, stated with the estimate: 5%); middle value at least 6.6-fold (0.82 log units) away from the limit.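

In this assay compound 4 gives > 100000 nM, which is a limit of the assay and not a number, so the true size of the change stays unknown: the limit of > 100000 nM in this assay, at which 2 of the 4 values shown sit.

Even so, the steps can be read as minimum sizes: fluoro in place of methoxy gives an at least 7.1-fold higher number from compound 3 to compound 4 (0.85 log units; beyond the scatter), and fluoro in place of hydrogen gives an at least 5.2-fold higher number from compound 2 to compound 4 (0.72 log units; beyond the scatter). This carbon had seemed indifferent while hydrogen and methoxy gave matching values, but it does respond to what sits there, and of these three groups only fluoro moves the number, towards weaker inhibition.

The compounds shown leave open whether this loss is special to fluoro or would also appear with chloro or an amine on the same carbon. They also leave open how far above the limit compound 4 really lies.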